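Removing the aryl ketone from a trimethoxyphenyl triazole

This account rests on a few compounds, and the source may have more. Where it says the series, first, only, none or still open, it means among the compounds named here.

Compound 1 `CCc1nnc(SCC(=O)c2ccc(C)cc2)n1N1C(=O)c2ccccc2C1=O`: > 200000 nM
Compound 2 `CCc1nnc(SC)n1N1C(=O)c2ccccc2C1=O`: > 200000 nM
Compound 3 `COc1cc(-c2nnc(SCC(=O)c3ccc(C)cc3)n2N2C(=O)c3ccccc3C2=O)cc(OC)c1OC`: 9440 nM

Of the compounds shown here, three have been tested in a functional assay on HepG2 cells (Homo sapiens) for cytotoxicity, read by MTT assay, with a stated time of 48 h; a lower number here means a stronger inhibitor, a higher number a weaker inhibitor. For compound 1 the value is a limit of the assay, > 200000 nM. For compound 2 the value is likewise a limit, > 200000 nM. Among the compounds with values here, compound 3 is the only one with a number, giving 9440 nM in this assay.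

Compound 3 differs from compound 1 by 3,4,5-trimethoxyphenyl in place of ethyl on an aromatic carbon, and this change gives an at least 21-fold lower number from compound 1 to compound 3 (1.32 log units; beyond the scatter). Compound 2 differs from compound 1 by hydrogen in place of (4-methylphenyl)carbonyl on a saturated chain carbon bound to a sulfur, but the two limits leave that step unreadable, a step that the two limits leave unreadable from compound 1 to compound 2, since both sit at the limit of > 200000 nM in this assay, at which 2 of the 3 values shown sit.

Compound 4 `COc1cc(-c2nnc(SC)n2N2C(=O)c3ccccc3C2=O)cc(OC)c1OC` is not yet measured. Within the data shown here, it differs from compound 3 by hydrogen in place of (4-methylphenyl)carbonyl on a saturated chain carbon bound to a sulfur, which is the same change as the one from compound 1 to compound 2, at the same place. Since that earlier step cannot be read, nothing in the measured compounds says how large it is. The only firm point is that compound 3 has a number at all, which rests on 9440 nM, while compound 2 does not.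

Compound 4 is therefore expected to give a weaker result than compound 3, with a 6.4-fold higher number from compound 3 to compound 4 (0.80 log units; beyond the scatter) as the estimated step, and a fair chance that only a limit is reported. The estimate for compound 4 is 60000 nM, between 15000 nM and 200000 nM.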

Compound 4, half-maximal inhibitory concentration: > 200000 nM
Compound 4: only a limit was reported; the forecaster's own chance of this, stated with the estimate: 40%; middle value at least 3.3-fold (0.52 log units) away from the limit.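

Cutting (4-methylphenyl)carbonyl back to hydrogen on the saturated chain carbon bound to a sulfur gives, in this assay, an at least 21-fold higher number from compound 3 to compound 4 (1.32 log units; beyond the scatter), so on the core of compound 3 the ((4-methylphenyl)carbonyl)methyl group goes with the only measured number in the set. Compound 4 itself gives only a limit of the assay, > 200000 nM. The same change on the core of compound 1 cannot be read, so the compounds do not show whether the step carries from one core to the other, and its full size on the core of compound 3 also remains unknown, with the values gathered at one end of the scale: the limit of > 200000 nM in this assay, at which 3 of the 4 values shown sit.

What the compounds shown leave open is which part of the departing group matters, the carbonyl or the 4-methylphenyl ring, and what an acetyl group, a benzyl group or a carboxylic acid would give in its place on the core of compound 3. From the compounds shown here alone, it also remains open whether a chlorine or a methoxy group in place of the methyl on that phenyl ring would keep a measurable number.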